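Adding one methyl group to compound 1

This account rests on a few compounds, and the source may have more. Where it says the series, first, only, none or still open, it means among the compounds named here.

In a functional assay on PC-3 cells (Homo sapiens) for antiproliferative activity, read by MTT assay, with a stated time of 48 h (on this read-out higher numbers stand for weaker inhibition and lower numbers for stronger inhibition), compound 1 (`O=C(/C=C/c1ccc(/C=C/C(=O)c2ccccc2)o1)NO`) gives 13300 nM. Compound 2 (`O=C(/C=C/c1ccc(/C=C/C(=O)c2cc(Cl)ccc2Cl)o1)NO`) gives 24700 nM, which lies within the usual scatter of compound 1, so the two cannot be told apart. Compound 3 (`O=C(NO)c1ccc(/C=C/c2cccc(Cl)c2Cl)o1`) gives 39300 nM, a number beyond the scatter from that of compound 1.

Compound 4 (`Cc1ccc(C(=O)/C=C/c2ccc(/C=C/C(=O)NO)o2)cc1`) turns the phenyl of compound 1 into 4-methylphenyl, with methyl in place of hydrogen on an aromatic carbon. For the measured compounds named here, no measured pair shows this change alone, so the expectation starts from compound 1 at 13300 nM, and no shift beyond the scatter is expected in this assay. The estimated step is a 1.1-fold higher number from compound 1 to compound 4 (0.02 log units; within the scatter). Compound 4 is expected at 14000 nM, within an estimated range of 6500 nM to 30000 nM.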

Compound 4, half-maximal inhibitory concentration: 16000 nM
Compound 4: the middle estimate sits 1.1-fold (0.06 log units) below what was measured; the measured number falls inside the stated range.
By their numbers in this assay, from the lowest: compounds 1, 4, 2 and 3 (each within the scatter of the next, the first and the last beyond it).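

In this assay, replacing phenyl with 4-methylphenyl gives a 1.2-fold higher number from compound 1 to compound 4 (0.08 log units; within the scatter). This is the first step shown that changes only one place, and it shows that a single methyl on the six-membered aromatic ring, para to a large group, produces no difference that can be told from ordinary scatter. A methyl group is only one small test of this position, so the result does not show how the position responds to other groups. On these data alone, whether an amine, a carboxylic acid or a longer chain in place of this methyl would move the number beyond the scatter stays open. No supporting measurement is available to explain this result.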